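One Pyrazole for Another on an Amide Nitrogen

A few compounds are considered here, and "the series" means these few. Any claim that something is new, unique, unknown or untested is made for them only; others in the source may bear on it.

Compound 1 `Cc1ccc(OCC(=O)N(Cc2cccs2)c2ccn(C)n2)cc1`: 855 nM
Compound 2 `CCN(Cc1ccncc1)C(=O)COc1ccc(C)cc1`: "not active" (no number reported)

In an assay on HEK293 cells for agonist activity at transient receptor potential cation channel subfamily M member 8 (Homo sapiens), read by fluorescence and calcium flux, with a stated time of 15 min (a lower number here means that less compound is needed, a higher number that more compound is needed for the effect), compound 1 gives 855 nM, and this is the only result that comes with a number. Compound 2 gives "not active" (no number reported) in this assay, so no number stands beside it. Compound 3 `Cc1ccc(OCC(=O)N(Cc2cccs2)c2ccn[nH]2)cc1` differs from compound 1 in one place: 1H-pyrazol-5-yl in place of 1-methyl-1H-pyrazol-3-yl on an amide-type nitrogen. Among the compounds with values here, no pair of measured compounds shows how a change of this kind moves the number, so the step is uncertain. For compound 3 a modest rise toward a higher number, just beyond the scatter, is expected, a 1.8-fold higher number from compound 1 to compound 3 (0.24 log units; within the scatter). Compound 3 is estimated at 1500 nM, between 400 nM and 6000 nM.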

Compound 3, half-maximal effective concentration: 0.2 nM
Estimate against measurement, compound 3: 7500-fold (3.88 log units) above; measured number outside the range, below it.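

In this assay the group on the amide-type nitrogen turns out to matter enormously: 1H-pyrazol-5-yl in place of 1-methyl-1H-pyrazol-3-yl gives a 4300-fold lower number from compound 1 to compound 3 (3.63 log units; beyond the scatter) on the otherwise shared core. Both groups are five-membered aromatic rings with 2 hetero atoms, so even a swap this small can move the number far beyond the scatter. Still open, going by these compounds, is how a phenyl group, or a 1-ethyl-1H-pyrazol-3-yl group, would read on that nitrogen. Nothing measured here explains the size of this step.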